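A few compounds are considered here, and "the series" means these few. Any claim that something is new, unique, unknown or untested is made for them only; others in the source may bear on it.

Compound 3, with structure `CNc1nc(C)c(-c2nc3ccccc3s2)c(N[C@@H]2C[C@H](CO)[C@@H](O)[C@H]2O)n1`, gives > 25000 nM in an ADME assay on cells (Homo sapiens) for cytotoxicity, read by polymerase chain reaction, with a stated time of 3 days (a higher number here means that more compound is tolerated, a lower number that less compound is tolerated), and this is a limit of the assay rather than a number. Compound 1, with structure `Nc1nc(Cl)c(-c2ncco2)c(N[C@@H]2C[C@H](CO)[C@@H](O)[C@H]2O)n1`, gives > 25000 nM in this assay, also a limit. Compound 2, with structure `CN(C)c1ccc2nc(-c3c(Cl)nc(N)nc3N[C@@H]3C[C@H](CO)[C@@H](O)[C@H]3O)sc2c1`, gives > 25000 nM in this assay, again a limit. All three values therefore sit at the limit of > 25000 nM in this assay, at which 3 of the 3 values shown sit. Compound 4, with structure `Cc1nc(NCC2CC2)nc(N[C@@H]2C[C@H](CO)[C@@H](O)[C@H]2O)c1-c1nc2ccccc2s1`, differs from compound 3 by cyclopropyl in place of hydrogen on a saturated chain carbon bound to a nitrogen on an aromatic ring. Among the measured compounds shown here, no step between measured compounds is known, so the effect of this change cannot be read from any pair; since every value so far is a limit, no step beyond the scatter in either direction is expected in this assay. Compound 4 is expected to give 25000 nM, between 12000 nM and 60000 nM. The step expected is a number no higher from compound 3 to compound 4 (the limit leaves the size open).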

Compound 4, half-maximal cytotoxic concentration: 8000 nM
Compound 4: middle estimate off by 3.1-fold (0.49 log units), on the high side; the whole stated range lies above it.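

In this assay the change gives an at least 3.1-fold lower number from compound 3 to compound 4 (0.49 log units; beyond the scatter), so cyclopropyl at this place, on a saturated chain carbon bound to a nitrogen on an aromatic ring, yields the first measured number rather than a limit. From the compounds shown here alone, compound 3 gives > 25000 nM, which is a limit, so the full size of the step stays unknown. The other compounds shown stay at that limit: the limit of > 25000 nM in this assay, at which 3 of the 4 values shown sit.

Going by these compounds, whether a propyl chain, a cyclobutyl or a phenyl in place of cyclopropyl would lower the number as far stays open. So does whether cyclopropyl has the same effect on the core of compound 1.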